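Moving one ring nitrogen on an aryl-linked imidazoline

A few compounds are considered here, and "the series" means these few. Any claim that something is new, unique, unknown or untested is made for them only; others in the source may bear on it.

Compound 1, `c1ccc(-c2ccncc2)c(OCC2=NCCN2)c1`, gives in a functional assay for activation of Alpha-1A adrenergic receptor (Homo sapiens), read by calcium flux (a lower number here means that less compound is needed, a higher number that more compound is needed for the effect), only a limit of the assay, < 100000 nM.
Compound 2, `Cc1cccnc1-c1ccccc1OCC1=NCCN1`, gives in this assay likewise only a limit, < 100000 nM.
Compound 3, `c1cnc(-c2ccccc2OCC2=NCCN2)nc1`, gives in this assay a real number, 1260 nM.

Going by the values given here, compound 3 therefore stands alone as the only compound with a readable value; the other two results sit at the limit (the limit of < 100000 nM in this assay, at which 2 of the 3 values shown sit). Among the compounds with values here, the single comparison between measured compounds, a step that the limit leaves unreadable from compound 1 to compound 3, cannot be given a size because compound 1 rests at the limit of < 100000 nM in this assay, at which 2 of the 3 values shown sit, so the data say only that a pyrimidin-2-yl group gives a measurable result where pyridin-4-yl does not.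

Compound 4, `c1ccc(-c2ccncn2)c(OCC2=NCCN2)c1`, has not yet been measured. It differs from compound 3 in one place: pyrimidin-4-yl in place of pyrimidin-2-yl on an aromatic carbon. Within the data shown here, no measured step bears directly on this change, and the one step that exists is unreadable, so the expectation rests on compound 3 alone and carries wide uncertainty. The step from compound 3 to compound 4 is estimated at a 3.2-fold higher number from compound 3 to compound 4 (0.50 log units; beyond the scatter), most likely toward needing somewhat more compound. Compound 4 is accordingly expected to give 4000 nM in this assay, with a plausible range from 800 nM to 30000 nM.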

Compound 4, half-maximal effective concentration: < 100000 nM
Compound 4: only a limit was reported; the forecaster's own chance of this, stated with the estimate: 30%; the middle value is on the limit's open side.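

Compound 4 gives only a limit in this assay, < 100000 nM. Its steps from compound 3 and from compound 1 therefore cannot be read: the limit of < 100000 nM in this assay, at which 3 of the 4 values shown sit.

Still open, from the compounds shown here alone, is how large the change from pyrimidin-2-yl to pyrimidin-4-yl really is, and whether compound 1, compound 2 and compound 4 differ from one another at all.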